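Compound 4: hydrogen in place of methoxy

A few compounds are considered here, and "the series" means these few. Any claim that something is new, unique, unknown or untested is made for them only; others in the source may bear on it.

In a functional assay on cells (Ovarian carcinoma cell, Homo sapiens) for cytotoxicity, read by sulforhodamine B assay, with a stated time of 48 h (a lower number here means a stronger inhibitor of growth, a higher number a weaker inhibitor of growth), compound 3 (`COc1ccc2c(c1)/C(=C\c1c(OC)nc3sc(C)cn13)C(=O)N2`) gives 1320 nM, within the scatter of compound 1 (`COc1ccc2c(c1)/C(=C/c1c(-c3ccncc3)nc3sccn13)C(=O)N2C`) at 1140 nM, whereas compound 2 (`COc1cc2c(cc1C)NC(=O)/C2=C/c1c(OC)nc2sc(C)cn12`) gives the clearly higher 7220 nM. Compound 4 (`COc1nc2sc(C)cn2c1/C=C1/C(=O)Nc2ccccc21`) has hydrogen in place of methoxy on an aromatic carbon. Within the data shown here, only one measured step is of a similar kind, a 5.5-fold lower number from compound 2 to compound 3 (0.74 log units; beyond the scatter), where hydrogen replaces methyl on an aromatic carbon. A different group leaves here, and that step is only a loose guide. A smaller change in the same direction is expected, possibly no larger than the scatter. The expected change is a 1.7-fold lower number from compound 3 to compound 4 (0.22 log units; within the scatter). The estimate for compound 4 is 800 nM, with the measurement expected between 230 nM and 2800 nM.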

Compound 4, concentration for 50% growth inhibition: 6290 nM
Estimate against measurement, compound 4: 7.9-fold (0.90 log units) below; measured number above the stated range.
By their numbers in this assay, from the lowest: compounds 1 and 3 (each within the scatter of the next); then compounds 4 and 2 (each within the scatter of the next).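

In this assay, the step of a 4.8-fold higher number from compound 3 to compound 4 (0.68 log units; beyond the scatter) shows that the methoxy on the six-membered aromatic ring of carbon only cannot be removed without loss of growth inhibition. Replacing a group on this ring with hydrogen therefore does not always act in one direction, since the earlier step of a 5.5-fold lower number from compound 2 to compound 3 (0.74 log units; beyond the scatter) went the other way when hydrogen replaced methyl. Nothing available explains this difference. As far as these compounds go, it remains open whether an ethoxy group, a hydroxyl or an amine in the place of the methoxy would keep the number of compound 3 or lower it.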